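Ring swap at the branching carbon: phenyl for cyclopentyl

The source may hold more compounds than are shown below. What is called first, only, known or untested is meant among the compounds shown, and "the series" means these compounds.

Compound 1 `O=C1NC(=O)/C(=C/C(c2ccc(-c3ccc4cccc(F)c4c3)[nH]c2=O)C2CCCCC2)O1`: 4 nM
Compound 2 `O=C1NC(=O)/C(=C/C(c2ccc(-c3ccc4cccc(F)c4c3)[nH]c2=O)C2CCCC2)O1`: 9 nM

Of the compounds shown here, two sharing one core have been measured in an assay on membranes from Chem-1 cells for displacement of a labelled ligand from prostaglandin E2 receptor EP3 subtype (Homo sapiens), read by scintillation counting, with a stated time of 2 h; a higher number here means a weaker inhibitor, a lower number a stronger inhibitor. Within the data shown here, compound 1 gives 4 nM and compound 2 gives 9 nM, so compound 2 carries the higher of the two numbers, with compound 1 as its only neighbour. Among the measured compounds shown here, the single measured step, a 2.3-fold higher number from compound 1 to compound 2 (0.35 log units; beyond the scatter), arose from cyclopentyl in place of cyclohexyl on the saturated chain carbon that is bound to an aromatic carbon and a double-bonded chain carbon.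

Compound 3 `O=C1NC(=O)/C(=C/C(c2ccccc2)c2ccc(-c3ccc4cccc(F)c4c3)[nH]c2=O)O1` changes the same position again: phenyl in place of cyclopentyl on a saturated chain carbon bound to an aromatic carbon and a double-bonded chain carbon. For the measured compounds named here, the one measured step bears on it only loosely, since phenyl is an aromatic six-membered ring rather than a saturated one, and no measured pair shows such an exchange. Compound 3 is therefore expected to give a weaker number, a 2.0-fold higher number from compound 2 to compound 3 (0.30 log units; within the scatter), with wide uncertainty. The estimate for compound 3 in this assay is 18 nM, ranging from 5 nM to 70 nM.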

Compound 3, inhibition constant: 23 nM
Compound 3: middle estimate off by 1.3-fold (0.11 log units), on the low side; the measured number falls inside the stated range.
By their numbers in this assay, from the lowest: compound 1; then compound 2; then compound 3.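

Putting phenyl in place of cyclopentyl on the saturated chain carbon bound to an aromatic carbon and a double-bonded chain carbon gave a 2.6-fold higher number from compound 2 to compound 3 (0.41 log units; beyond the scatter) in this assay, and putting it in place of cyclohexyl gave a 5.8-fold higher number from compound 1 to compound 3 (0.76 log units; beyond the scatter). Among these compounds, this is the first aromatic ring seen at this position, and both saturated rings give lower numbers than it, with no compound here going against that order. The position therefore tolerates phenyl, but at a measurable cost compared with either saturated ring. Nothing available explains this order.

Going by these compounds, it remains open whether an amine or a carboxylic acid on the phenyl would move the number in either direction. A longer chain in place of the ring is equally unresolved, as is whether any ring is needed at this position.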